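Compound 3 at the limit of a cell assay

The compounds below may be only part of what the source reports. "The series", "measured", "known", "first", "only" and "open" are said of these compounds alone.

Measured in a functional assay on COLO 205 cells (Homo sapiens) for inhibition, read by sulforhodamine B assay, with a stated time of 48 h; a higher number here means that more compound is tolerated, a lower number that less compound is tolerated:
- compound 1 `Cc1ccc(C2=NN(c3ccc(S(C)(=O)=O)cc3)C(=O)CC2)cc1`: > 100000 nM (a limit)
- compound 2 `Cc1cc(O)ccc1C1=NN(c2ccc(S(C)(=O)=O)cc2)C(=O)CC1`: > 100000 nM (a limit)

Compound 2 stands only at a limit, > 100000 nM, with no number known for it. Both measured compounds sit at the limit of > 100000 nM in this assay, at which 2 of the 2 values shown sit. Compound 3 `CCc1ccc(C2=NN(c3ccc(S(C)(=O)=O)cc3)C(=O)CC2)cc1` carries 4-ethylphenyl in place of 4-hydroxy-2-methylphenyl on a carbon with a double bond to nitrogen, (4-ethylphenyl in place of 4-hydroxy-2-methylphenyl on a carbon with a double bond to nitrogen). Among the measured compounds shown here, the only measured step, a step that the two limits leave unreadable from compound 1 to compound 2, bears on this change, but it gives no size. In this assay the expected result is a number no higher from compound 2 to compound 3 (the limit leaves the size open), so no step beyond the scatter is anticipated. Compound 3 is expected at 100000 nM, with an estimated range of 50000 nM to 200000 nM.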

Compound 3, concentration lethal to 50% of the cells: 83800 nM
Estimate against measurement, compound 3: 1.2-fold (0.08 log units) above; the range from low to high includes it.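

With 4-ethylphenyl on a carbon with a double bond to nitrogen, compound 3 gives a number in this assay, whereas compound 1 and compound 2 give only a limit: the limit of > 100000 nM in this assay, at which 2 of the 3 values shown sit.

The change gives an at least 1.1-fold lower number from compound 2 to compound 3 (0.07 log units; that floor lies within the scatter), and the added methyl gives an at least 1.1-fold lower number from compound 1 to compound 3 (0.07 log units; that floor lies within the scatter). From the compounds shown here alone, each step is only a floor, and its full size stays unknown.

The compounds shown leave open whether a longer chain, such as propyl, or an amine in this place would give a clearly lower number.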